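Swapping the methylated azole ring: from oxadiazole to tetrazole

This account rests on a few compounds, and the source may have more. Where it says the series, first, only, none or still open, it means among the compounds named here.

Of the compounds shown here, three sharing one core have been measured in a functional assay on CHO cells for antagonist activity at B1 bradykinin receptor (Homo sapiens), read by FLIPR and calcium flux; a lower number here means a stronger inhibitor, a higher number a weaker inhibitor. Compound 1 `Cc1nc(-c2c(F)cccc2-c2ccc([C@@H](C)Nc3nccc(Cl)c3NC(=O)CC#N)cc2)no1` gives 0.78 nM. Compound 2 `COC(=O)c1ccc(Cl)cc1-c1ccc([C@@H](C)Nc2nccc(Cl)c2NC(=O)CC#N)cc1` gives 1.5 nM. Compound 3 `Cc1noc(-c2c(F)cccc2-c2ccc([C@@H](C)Nc3nccc(Cl)c3NC(=O)CC#N)cc2)n1` gives 0.94 nM, the second highest of the three numbers; its nearest neighbour is compound 1 and its furthest is compound 2, and both gaps are within the scatter of this assay, so none of the three can be called apart from the others.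

Compound 4 `C[C@@H](Nc1nccc(Cl)c1NC(=O)CC#N)c1ccc(-c2cccc(F)c2-c2nnn(C)n2)cc1` is not yet measured. It differs from compound 3 in one place: 2-methyl-2H-tetrazol-5-yl in place of 3-methyl-1,2,4-oxadiazol-5-yl on an aromatic carbon. Going by the values given here, the only measured step that bears on this kind of change is the one that moves the methyl group around the same five-membered ring, a 1.2-fold higher number from compound 1 to compound 3 (0.08 log units; within the scatter), which stayed within the scatter. Among the compounds with values here, that single step is slim evidence, and no measured pair shows what replacing the oxadiazole by a tetrazole does here, so the expectation for compound 4 in this assay is no step beyond the scatter.

Compound 4 is therefore estimated at 1.1 nM, with a range from 0.4 nM to 3 nM, which means an expected step of a 1.2-fold higher number from compound 3 to compound 4 (0.07 log units; within the scatter).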

Compound 4, half-maximal inhibitory concentration: 1.17 nM
Compound 4: the middle estimate sits 1.1-fold (0.03 log units) below what was measured; measured number inside the range.
By their numbers in this assay, from the lowest: compounds 1, 3, 4 and 2 (each within the scatter of the next).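

In this assay, replacing one ring type with another on this aromatic carbon, ortho to a fluoro group, gives a 1.2-fold higher number from compound 3 to compound 4 (0.10 log units; within the scatter), and measured against the other oxadiazole the same tetrazole gives a 1.5-fold higher number from compound 1 to compound 4 (0.18 log units; within the scatter). Going by these compounds alone, until now the only step at this place moved the methyl group and the ring nitrogen around a 1,2,4-oxadiazole, whereas this change alters the ring itself: 2-methyl-2H-tetrazol-5-yl has the same number of heavy atoms, but 4 hetero atoms instead of 3 and no ring oxygen, and the numbers still cannot be told apart. So at this position, the three methylated rings are interchangeable within the scatter of this measurement, though no evidence is available on why that is so.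

The compounds shown leave open whether a longer chain on the tetrazole, such as ethyl or propyl, or a carboxylic acid or an amine on the same aromatic carbon, would stay in the same range. From the compounds shown here alone, compound 1, compound 3 and compound 4 all carry the fluoro group, so whether this tolerance holds with a hydrogen in its place also remains open.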